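This account rests on a few compounds, and the source may have more. Where it says the series, first, only, none or still open, it means among the compounds named here.

Three flavone-type compounds share an amino- or nitrophenyl substituent and were tested in a functional assay on A549 cells (Homo sapiens) for cytotoxicity, read by MTT assay, with a stated time of 6 days; a higher number here means that more compound is needed for the effect, a lower number that less compound is needed. Compound 1, `O=c1cc(-c2ccc([N+](=O)[O-])cc2)oc2ccc(O)cc12`, gives 5.07 ug/mL. Compound 2, `O=c1cc(-c2ccc([N+](=O)[O-])cc2)oc2cc(O)ccc12`, has the same atoms joined differently, and how the two cores differ is not broken down here; in this assay compound 2 gives 21.8 ug/mL, the highest of the three numbers, beyond the scatter against compound 1. Compound 3, `Nc1ccc(-c2cc(=O)c3cc(O)ccc3o2)cc1`, gives 2.72 ug/mL. Between compound 1 and compound 3 the change is amino in place of nitro on an aromatic carbon, and the step is a 1.9-fold lower number from compound 1 to compound 3 (0.27 log units; within the scatter).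

Compound 4, `Nc1ccc(-c2cc(=O)c3ccc(O)cc3o2)cc1`, awaits measurement. It differs from compound 2 by amino in place of nitro on an aromatic carbon, the same change made from compound 1 to compound 3, at the same place. On this one precedent the step from compound 2 to compound 4 is expected to be modest, about a 1.7-fold lower number from compound 2 to compound 4 (0.22 log units; within the scatter), because the earlier step was a 1.9-fold lower number from compound 1 to compound 3 (0.27 log units; within the scatter). Compound 4 is therefore estimated at 13 ug/mL in this assay, with a likely range from 6 ug/mL to 30 ug/mL.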

Compound 4, concentration for half-maximal effect: 8.87 ug/mL
Estimate against measurement, compound 4: 1.5-fold (0.17 log units) above, and the stated range covers the measured number.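

Carried to the other core, amino in place of nitro on an aromatic carbon gives a 2.5-fold lower number from compound 2 to compound 4 (0.39 log units; beyond the scatter) in this assay. The new step and the earlier one point the same way, and their sizes cannot be told apart: the same change on two cores in this assay, a 1.9-fold lower number (0.27 log units; within the scatter) from compound 1 to compound 3 and a 2.5-fold lower number (0.39 log units; beyond the scatter) from compound 2 to compound 4, 1.3-fold (0.12 log units) apart, within the scatter of two such steps

Within these two pairs, then, the change carries from one core to the other with a similar size, although only the new step lies beyond the scatter. This rests on two pairs in a single assay, and it does not show what lies behind the step or whether it would hold on any further core.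

The compounds shown leave open whether a different group on the same aromatic carbon, such as a carboxylic acid, a methoxy or an amine with a longer chain, would fit the same picture. They also leave open how the numbers would respond if a methoxy took the place of the hydroxyl on either core.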